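The source may report more compounds than this note shows. Statements on the series, on what has been measured and on what is new or still open speak of the compounds shown alone.

Of the compounds shown here, three sharing one core have been measured in an assay on CHO cells for displacement of a labelled ligand from 5-hydroxytryptamine receptor 1B (Homo sapiens); a higher number here means a weaker inhibitor, a lower number a stronger inhibitor. Compound 1 `O=S(=O)(NCC1CCN(CCCc2c[nH]c3ccc(-n4cnnc4)cc23)CC1)c1ccccc1` gives 60 nM, compound 2 `CC(=O)Nc1ccc(CNC2CCN(CCCc3c[nH]c4ccc(-n5cnnc5)cc34)CC2)cc1` gives 45 nM, and compound 3 `c1ccc(CNCC2CCN(CCCc3c[nH]c4ccc(-n5cnnc5)cc34)CC2)cc1` gives 28 nM, the lowest of the three; compound 2 lies within the scatter of compound 3, while compound 1 lies beyond it. Among the compounds with values here, the one measured step, a 2.1-fold lower number from compound 1 to compound 3 (0.33 log units; beyond the scatter), was modest. Compound 4 `c1cncc(CNC2CCN(CCCc3c[nH]c4ccc(-n5cnnc5)cc34)CC2)c1` differs from compound 3 by ((pyridin-3-yl)methyl)amino in place of (benzylamino)methyl on a saturated ring carbon. Within the data shown here, no measured step matches this change directly; the closest guide is compound 2, which also carries the amine on a saturated ring carbon. Because compound 2 gives 45 nM, a number within the scatter of compound 3, no step beyond the scatter is expected, that is a 1.4-fold higher number from compound 3 to compound 4 (0.15 log units; within the scatter). Compound 4 is therefore expected at 40 nM, ranging from 18 nM to 90 nM.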

Compound 4, half-maximal inhibitory concentration: 140 nM
The estimate for compound 4 lay 3.5-fold (0.54 log units) below the measured number; measured number outside the range, above it.
By their numbers in this assay, from the lowest: compounds 3, 2 and 1 (each within the scatter of the next, the first and the last beyond it); then compound 4.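

In this assay the change on this saturated ring carbon gives a 5.0-fold higher number from compound 3 to compound 4 (0.70 log units; beyond the scatter), so this position does not accept every amine-bearing group equally. With the amine on the ring carbon in both compounds, changing only the aromatic group gives a 3.1-fold higher number from compound 2 to compound 4 (0.49 log units; beyond the scatter), so the amine's placement alone cannot account for the rise. The pyridine compound also falls behind the phenylsulfonyl compound, with a 2.3-fold higher number from compound 1 to compound 4 (0.37 log units; beyond the scatter).

Nothing available explains this rise. Open, from the compounds shown here alone, is whether a plain phenyl on the same ring-carbon amine would match compound 3 or compound 4, which would separate the pyridine nitrogen from the amine's placement.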